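A few compounds are considered here, and "the series" means these few. Any claim that something is new, unique, unknown or untested is made for them only; others in the source may bear on it.

Measured in a functional assay on MCF7 cells (Homo sapiens) for inhibition, read by MTT assay, with a stated time of 72 h; a lower number here means a stronger inhibitor, a higher number a weaker inhibitor:

- Compound 1 `Cc1cc(Nc2cc(-c3ccccc3)[nH]n2)n2nc(SCc3c(Cl)cccc3Cl)nc2n1`: 3230 nM
- Compound 2 `Cc1cc(Nc2cc(-c3ccccc3)[nH]n2)n2nc(SCc3cccc(Br)c3)nc2n1`: 5140 nM
- Compound 3 `C#CCSc1nc2nc(C)cc(Nc3cc(-c4ccccc4)[nH]n3)n2n1`: 21800 nM

Of these three, compound 3 has the highest number and is the weakest inhibitor in this assay, at 21800 nM. The next structure, compound 4 `Cc1cc(Nc2cc(-c3ccccc3)[nH]n2)n2nc(SCc3nc4ccccc4[nH]3)nc2n1`, keeps the shared core and differs only in the group on a saturated chain carbon bound to a sulfur: 1H-benzimidazol-2-yl in place of ethynyl on a saturated chain carbon bound to a sulfur. Going by the values given here, no measured compound carries 1H-benzimidazol-2-yl, so the closest guides are the two measured compounds with a substituted phenyl group at this place. Putting ethynyl in place of those groups gave modest steps to a higher number: a 4.2-fold higher number from compound 2 to compound 3 (0.63 log units; beyond the scatter) and a 6.7-fold higher number from compound 1 to compound 3 (0.83 log units; beyond the scatter). Exchanging one substituted phenyl group for the other stayed within the scatter: a 1.6-fold higher number from compound 1 to compound 2 (0.20 log units; within the scatter). If 1H-benzimidazol-2-yl tracks those two groups, leaving ethynyl should undo a step of about that modest size, though this remains an extrapolation to an untested group. A move to a lower number is therefore expected, and the estimated change is a 4.0-fold lower number from compound 3 to compound 4 (0.60 log units; beyond the scatter). Compound 4 is expected at 5500 nM, with an estimated range from 1800 nM to 16000 nM.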

Compound 4, half-maximal inhibitory concentration: 2730 nM
For compound 4 the middle estimate is 2.0-fold (0.30 log units) above the measured one; the measured number falls inside the stated range.
By their numbers in this assay, from the lowest: compounds 4, 1 and 2 (each within the scatter of the next); then compound 3.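

In this assay, replacing ethynyl with 1H-benzimidazol-2-yl gives an 8.0-fold lower number from compound 3 to compound 4 (0.90 log units; beyond the scatter) and shows that the change away from ethynyl at this place on a saturated chain carbon bound to a sulfur also holds for a group that is not a substituted phenyl. Compared directly with those substituted phenyl groups, the same group gives a 1.9-fold lower number from compound 2 to compound 4 (0.27 log units; within the scatter) and a 1.2-fold lower number from compound 1 to compound 4 (0.07 log units; within the scatter) and so cannot be told apart from either of them in this assay. Among the four compounds, the entry of two ring nitrogens and a hydrogen-bond donor therefore brings no separation from the halogen-bearing phenyl groups, and only compound 3 with its ethynyl group stands apart from compound 4.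

No accompanying measurement gives a reason for the step from ethynyl or for the close agreement among the three larger groups. The compounds shown also leave open whether 1-methyl-1H-benzimidazol-2-yl, which lacks the ring hydrogen-bond donor, an unsubstituted phenyl, a simple amine or a carboxylic acid at this place would stay level with compound 4 or fall back towards compound 3.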